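This account rests on a few compounds, and the source may have more. Where it says the series, first, only, none or still open, it means among the compounds named here.

Compound 1 `Fc1ccc(CN2CCC(NCCSC(c3ccc(F)cc3)c3ccc(F)cc3)CC2)cc1` gives 13.3 nM in an assay on membranes from Cortex for displacement of a labelled ligand from Sigma non-opioid intracellular receptor 1 (Cavia porcellus), read by scintillation counting, with a stated time of 120 min (on this read-out lower numbers stand for stronger inhibition and higher numbers for weaker inhibition), the lowest of the three numbers measured in this series. Compound 2 `O=C(c1ccc(F)cc1)N1CCC(NCCSC(c2ccc(F)cc2)c2ccc(F)cc2)CC1` gives 32.1 nM and compound 3 `CC(C)(C)CN1CCC(NCCSC(c2ccc(F)cc2)c2ccc(F)cc2)CC1` gives 315 nM. Compound 4 `O=C(c1ccccc1F)N1CCC(NCCSC(c2ccc(F)cc2)c2ccc(F)cc2)CC1` is not yet measured; it differs from compound 1 in one place: (2-fluorophenyl)carbonyl in place of 4-fluorobenzyl on an amine nitrogen in a ring. The step that bears most directly is a 2.4-fold higher number from compound 1 to compound 2 (0.38 log units; beyond the scatter), where the same carbonyl link to a fluorophenyl ring entered at the same nitrogen. Compound 4 carries (2-fluorophenyl)carbonyl where compound 2 carries (4-fluorophenyl)carbonyl, and for that pair no measurement exists. The step of a 24-fold higher number from compound 1 to compound 3 (1.37 log units; beyond the scatter) concerns a different group and bears less. A modest upward step is therefore expected, a 2.3-fold higher number from compound 1 to compound 4 (0.35 log units; beyond the scatter). Compound 4 is estimated at 30 nM, with a range of 12 nM to 80 nM.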

Compound 4, inhibition constant: 3.57 nM
Beside the measured number, compound 4's estimate is 8.4-fold (0.92 log units) above it; measured number below the stated range.
By their numbers in this assay, from the lowest: compound 4; then compound 1; then compound 2; then compound 3.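

In this assay, a carbonyl link at the amine nitrogen in a ring does not by itself raise the number: (2-fluorophenyl)carbonyl gives a 3.7-fold lower number from compound 1 to compound 4 (0.57 log units; beyond the scatter), opposite in direction to a 2.4-fold higher number from compound 1 to compound 2 (0.38 log units; beyond the scatter). The outcome depends on the fluorophenyl group on the carbonyl carbon, with 2-fluorophenyl in place of 4-fluorophenyl giving a 9.0-fold lower number from compound 2 to compound 4 (0.95 log units; beyond the scatter), while the replacement of neopentyl gives an 88-fold lower number from compound 3 to compound 4 (1.95 log units; beyond the scatter). No supporting evidence on the origin of these differences is available.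

Open, from the compounds shown here alone, is whether 2-chlorophenyl or 2-methoxyphenyl on the carbonyl carbon gives a similar number. Also open, going by these compounds, is whether 2-fluorobenzyl on the amine nitrogen shifts the number in the same direction.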